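Trifluoromethyl moved to the 4-position of the phenyl ether

The compounds below may be only part of what the source reports. "The series", "measured", "known", "first", "only" and "open" are said of these compounds alone.

Three measured compounds share one core and differ only in the aryl group on the ether oxygen. Compound 1 `O=C(O)c1csc([C@H]2CC[C@@H]3[C@@H](COc4cccc(F)c4)[C@H](O)C[C@@H]3O2)n1` carries 3-fluorophenyl and gives 5.4 nM in a functional assay on CHO cells for agonist activity at prostaglandin E2 receptor EP2 subtype (Homo sapiens), read by HTRF and cAMP accumulation, with a stated time of 30 min; a lower number here means that less compound is needed, a higher number that more compound is needed for the effect. Compound 2 `O=C(O)c1csc([C@H]2CC[C@@H]3[C@@H](COc4ccccc4C(F)(F)F)[C@H](O)C[C@@H]3O2)n1` carries 2-(trifluoromethyl)phenyl and gives 0.5 nM. Compound 3 `O=C(O)c1csc([C@H]2CC[C@@H]3[C@@H](COc4ccccc4Cl)[C@H](O)C[C@@H]3O2)n1` carries 2-chlorophenyl and gives 3.3 nM; among the three numbers it stands second highest, close to compound 1 and well apart from compound 2, as the step of a 6.6-fold higher number from compound 2 to compound 3 (0.82 log units; beyond the scatter) shows.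

Compound 4 `O=C(O)c1csc([C@H]2CC[C@@H]3[C@@H](COc4ccc(C(F)(F)F)cc4)[C@H](O)C[C@@H]3O2)n1` differs from compound 3 as follows: 4-(trifluoromethyl)phenyl in place of 2-chlorophenyl on an oxygen on a saturated carbon.

Among the measured compounds shown here, two steps bear on this change. The step of a 6.6-fold higher number from compound 2 to compound 3 (0.82 log units; beyond the scatter) shows that trifluoromethyl on the aromatic carbon gives a lower number than chloro at the same position, and the step of an 11-fold lower number from compound 1 to compound 2 (1.03 log units; beyond the scatter) shows that 2-(trifluoromethyl)phenyl gives the lowest number of the set. For the measured compounds named here, compound 4 keeps trifluoromethyl but at the 4-position, and no measured pair shows a change of position for an unchanged group, so the direction is supported only in part. A moderate step downward is therefore expected for compound 4, as a 1.8-fold lower number from compound 3 to compound 4 (0.26 log units; within the scatter), with wide bounds. The estimate for compound 4 is 1.8 nM, between 0.5 nM and 8 nM.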

Compound 4, half-maximal effective concentration: 13 nM
Compound 4: middle estimate off by 7.2-fold (0.86 log units), on the low side; the measured number lies above the stated range.
By their numbers in this assay, from the lowest: compound 2; then compounds 3 and 1 (each within the scatter of the next); then compound 4.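

In this assay the pair that keeps trifluoromethyl and changes only its place on the phenyl ring gives a 26-fold higher number from compound 2 to compound 4 (1.41 log units; beyond the scatter) and so shows that the low number of compound 2 belongs to 2-(trifluoromethyl)phenyl and not to trifluoromethyl wherever it stands on the ring. The other two steps, a 3.9-fold higher number from compound 3 to compound 4 (0.60 log units; beyond the scatter) and a 2.4-fold higher number from compound 1 to compound 4 (0.38 log units; beyond the scatter), put 4-(trifluoromethyl)phenyl above both 2-chlorophenyl and 3-fluorophenyl, so compound 4 has the highest number of the four, with all three of its steps beyond the scatter. Nothing measured here gives a reason for this rise.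

From the compounds shown here alone, whether chloro and fluoro also depend on where they sit on the phenyl ring stays open, since only one placement of each appears in the set. Also open, going by these compounds, is how the number responds to groups of another kind on the phenyl ring, such as methoxy or nitrile, or to a pyridine ring in place of the phenyl.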